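This account rests on a few compounds, and the source may have more. Where it says the series, first, only, none or still open, it means among the compounds named here.

Of the compounds shown here, two with the shared core have so far been read in a functional assay on U-87MG ATCC cells for cytotoxicity against U-87 MG (Homo sapiens), read by MTT assay, with a stated time of 48 h; on this read-out higher numbers stand for weaker inhibition and lower numbers for stronger inhibition. There, compound 1 `O=C(COc1ccc(/C=C/C(=O)c2ccc(F)cc2)cc1)Nc1ccc2c(c1)COC2=O` gives 6050 nM and compound 2 `COc1ccc(/C=C/C(=O)c2ccc(OCC(=O)Nc3ccc4c(c3)COC4=O)cc2)cc1` gives 4900 nM. Compound 2 therefore stands level with compound 1, as the two values lie within the scatter of each other.

The next compound to be read is compound 3 `COc1cccc(/C=C/C(=O)c2ccc(OCC(=O)Nc3ccc4c(c3)COC4=O)cc2)c1`. Its difference from compound 2 is 3-methoxyphenyl in place of 4-methoxyphenyl on a double-bonded chain carbon bound to a double-bonded chain carbon. The two have the same atoms, joined differently.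

Among the compounds with values here, no pair of measured compounds differs in one place only, so the data offer no direct measure of what such a change does in this assay. No step beyond the scatter is expected, and no direction can be favoured. This expectation takes compound 2 at 4900 nM as its starting point. The estimated step is a 1.0-fold higher number from compound 2 to compound 3 (0.01 log units; within the scatter), which is expected to stay within the scatter. For compound 3 the expected value is 5000 nM, with an estimated range of 2200 nM to 11000 nM.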

Compound 3, half-maximal inhibitory concentration: 5750 nM
The estimate for compound 3 lay 1.2-fold (0.06 log units) below the measured number; the measured number falls inside the stated range.
By their numbers in this assay, from the lowest: compounds 2, 3 and 1 (each within the scatter of the next).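

In this assay, the exchange of 4-methoxyphenyl for 3-methoxyphenyl on a double-bonded chain carbon bound to a double-bonded chain carbon gives the first direct measure of a single change in this series (a 1.2-fold higher number from compound 2 to compound 3 (0.07 log units; within the scatter)). The two compounds hold the same atoms joined differently, and this read-out does not separate them, so at this place the exchange of one methoxyphenyl for the other shows no effect beyond the scatter. Nothing available on these compounds offers any explanation for this result.

What the compounds shown leave open is whether a group other than methoxy on that phenyl ring, such as a hydroxyl, an amine or a carboxylic acid, would move the number in this assay beyond the scatter. They also leave open whether a longer chain, such as ethoxy or propoxy, in place of the methoxy group would stay level with compound 2 and compound 3, and whether either of the two methoxyphenyl groups could be told apart from the other on any other read-out.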